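Chlorophenyl in place of cyanophenyl on the thiosemicarbazone nitrogen

The compounds below may be only part of what the source reports. "The series", "measured", "known", "first", "only" and "open" are said of these compounds alone.

Measured so far:
compound 1, `N#Cc1ccc(NC(=S)N/N=C/c2ccc3ccccc3n2)cc1`, 23700 nM
compound 2, `NC(=S)N/N=C/c1cnc2ccccc2n1`, > 100000 nM

In a functional assay on SGC-7901 cells (Homo sapiens) for antiproliferative activity, read by sulforhodamine B assay, with a stated time of 72 h (on this read-out lower numbers stand for stronger inhibition and higher numbers for weaker inhibition), compound 1 gives 23700 nM. Compound 2 reaches only a limit of the assay, > 100000 nM. Within the data shown here, compound 1 therefore holds the only numerical value of the pair, the other being (the limit of > 100000 nM in this assay, at which 1 of the 2 values shown sits). Among the measured compounds shown here, no step between measured compounds exists here, since compound 1 and compound 2 differ in more than one place; of that pair one can say only what the two values show.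

Compound 3, `S=C(N/N=C/c1ccc2ccccc2n1)Nc1cccc(Cl)c1`, has not been measured. It differs from compound 1 as follows: 3-chlorophenyl in place of 4-cyanophenyl on an amide-type nitrogen. For the measured compounds named here, no measured step bears on this change, so the step in this assay is expected to stay within the scatter, in no particular direction. Compound 3 is accordingly estimated at 25000 nM, with a range from 8000 nM to 80000 nM, which corresponds to an expected step of a 1.1-fold higher number from compound 1 to compound 3 (0.02 log units; within the scatter).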

Compound 3, half-maximal inhibitory concentration: 61300 nM
Compound 3: middle estimate off by 2.5-fold (0.39 log units), on the low side; low and high end bracket the measured number.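

In this assay, 3-chlorophenyl in place of 4-cyanophenyl on the amide-type nitrogen gives a 2.6-fold higher number from compound 1 to compound 3 (0.41 log units; beyond the scatter) and so shows that the group at this position can shift the antiproliferative read-out. Among these compounds, of the two groups compared here, 4-cyanophenyl gives the lower number and thus the stronger inhibition, a comparison that was unavailable while no step had been measured. Nothing in the data shown explains why the number moves.

The change alters both the substituent and its printed ring position, so the compounds shown cannot separate these two contributions. They also leave open how a methoxy group or an amine on this phenyl ring, or a saturated morpholine ring in place of it, would affect the read-out.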